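Acetyl for ethyl in a cell tolerance test

The source may hold more compounds than are shown below. What is called first, only, known or untested is meant among the compounds shown, and "the series" means these compounds.

Compound 1 `O=C(NC(=S)Nc1cccc(C(F)(F)F)c1)c1ccccc1`: > 100000 nM (a limit)
Compound 2 `N#Cc1ccc(NC(=S)Nc2cccc(C(F)(F)F)c2)cc1`: 9500 nM
Compound 3 `CCNC(=S)Nc1cccc(C(F)(F)F)c1`: > 100000 nM (a limit)

All three compounds were tested in an ADME assay on BHK cells (Mesocricetus auratus) for cytotoxicity, read by MTT assay, with a stated time of 96 h; a lower number here means that less compound is tolerated, a higher number that more compound is tolerated. There, compound 3 gives > 100000 nM, which is a limit and not a number. Compound 1 gives > 100000 nM, and this too is a limit. The shared ceiling can be stated as the limit of > 100000 nM in this assay, at which 2 of the 3 values shown sit. Only compound 2, at 9500 nM, has an actual number.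

Compound 4 `CC(=O)NC(=S)Nc1cccc(C(F)(F)F)c1` starts from compound 3 and has acetyl in place of ethyl on an amide-type nitrogen. Among the compounds with values here, no measured pair shows this exact change, so any expectation rests on thin ground. Compound 1 also has a carbonyl on that nitrogen, and its reading of > 100000 nM gives no sign of lower tolerance. Compound 2, at 9500 nM, shows that a real number can appear with this core, so the expected range stays wide on the lower side. Overall, no change beyond the usual scatter is expected in this assay, and the reading may again be only a limit. The expected step is an at least 1.1-fold lower number from compound 3 to compound 4 (0.04 log units; that floor lies within the scatter). For compound 4 the estimate is 90000 nM, with an expected range of 30000 nM to 200000 nM.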

Compound 4, half-maximal cytotoxic concentration: > 100000 nM
Compound 4: no number, only a limit; the forecaster's own chance of this, stated with the estimate: 60%; at least 1.1-fold (0.04 log units) between middle value and limit.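

In this assay compound 4 gives > 100000 nM, which is a limit and not a number, and no step from it to compound 3 or compound 1 can be read because all three share one ceiling: the limit of > 100000 nM in this assay, at which 3 of the 4 values shown sit.

The compounds shown leave open whether acetyl in place of ethyl changes cell tolerance at all.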